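Swapping One Aromatic Ring for Another at the Carbonyl

A few compounds are considered here, and "the series" means these few. Any claim that something is new, unique, unknown or untested is made for them only; others in the source may bear on it.

Of the compounds shown here, three sharing one core have been tested in a functional assay on SK-OV-3 cells (Homo sapiens) for cytotoxicity, read by MTT assay, with a stated time of 48 h; a higher number here means a weaker inhibitor, a lower number a stronger inhibitor. Compound 1 `O=C(/C=C/c1ccc2c(c1)B(O)OC2)c1cccnc1` gives 18500 nM, the highest of the three numbers, with both other compounds beyond the scatter below it. For the measured compounds named here, compound 2 `CCc1ccc(C(=O)/C=C/c2ccc3c(c2)B(O)OC3)cc1` gives 4400 nM and compound 3 `CSc1ccc(C(=O)/C=C/c2ccc3c(c2)B(O)OC3)cc1` gives 4100 nM; the only single-change step among them, a 1.1-fold lower number from compound 2 to compound 3 (0.03 log units; within the scatter), lies within the scatter. Compound 4 `O=C(/C=C/c1ccc2c(c1)B(O)OC2)c1ccccc1F` differs from compound 1 only on a carbonyl carbon: 2-fluorophenyl in place of pyridin-3-yl on a carbonyl carbon. Going by the values given here, no measured step swaps the ring on that carbon, so the comparison is indirect: compounds 2 and 3, which also carry a ring of carbon only there, both sit well below compound 1. A downward step is therefore expected, a 2.6-fold lower number from compound 1 to compound 4 (0.42 log units; beyond the scatter). Compound 4 is estimated at 7000 nM, likely between 3000 nM and 18000 nM.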

Compound 4, half-maximal inhibitory concentration: 3700 nM
Compound 4: the middle estimate sits 1.9-fold (0.28 log units) above what was measured; the measured number falls inside the stated range.
By their numbers in this assay, from the lowest: compounds 4, 3 and 2 (each within the scatter of the next); then compound 1.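

In this assay the swap on a carbonyl carbon gives a 5.0-fold lower number from compound 1 to compound 4 (0.70 log units; beyond the scatter) and lies beyond the scatter. For the compounds shown here, this is the first direct measurement of a ring change at this position, and it shows that the number responds to which ring sits there. No evidence at hand explains the drop.

The swap removes the ring nitrogen and adds a fluorine in one move, so the compounds shown leave open how much of the step belongs to each. A plain phenyl ring on the same carbon would separate the two.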